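A few compounds are considered here, and "the series" means these few. Any claim that something is new, unique, unknown or untested is made for them only; others in the source may bear on it.

Compound 1 `COC(=O)C(Nc1cc(NS(=O)(=O)/C=C/c2c(OC)cc(OC)cc2OC)ccc1OC)c1ccc(Cl)cc1` and compound 2 `COC(=O)C(Nc1cc(NS(=O)(=O)/C=C/c2c(OC)cc(OC)cc2OC)ccc1OC)c1ccc(Br)cc1` share one core and differ only in bromo in place of chloro on an aromatic carbon. In a functional assay on DU-145 cells (Homo sapiens) for cytotoxicity, read by trypan blue exclusion, with a stated time of 96 h (on this read-out lower numbers stand for stronger inhibition and higher numbers for weaker inhibition), compound 1 gives 5000 nM, and compound 2 gives 7500 nM; this change made a 1.5-fold higher number from compound 1 to compound 2 (0.18 log units; within the scatter). Compound 3 `COc1cc(OC)c(/C=C/S(=O)(=O)Nc2ccc(OC)c(NC(C(=O)O)c3ccc(Cl)cc3)c2)c(OC)c1` carries a different core, set apart from compound 1 by hydrogen in place of methyl on an oxygen next to a carbonyl group; in this assay compound 3 gives 75 nM, which is a 67-fold lower number from compound 1 to compound 3 (1.82 log units; beyond the scatter). Compound 4 `COc1cc(OC)c(/C=C/S(=O)(=O)Nc2ccc(OC)c(NC(C(=O)O)c3ccc(Br)cc3)c2)c(OC)c1` has not yet been measured and differs from compound 3 in bromo in place of chloro on an aromatic carbon, the same change as between compound 1 and compound 2, made at the same place. For compound 4 in this assay a step of a 1.5-fold higher number from compound 3 to compound 4 (0.17 log units; within the scatter) is expected, because the earlier step of a 1.5-fold higher number from compound 1 to compound 2 (0.18 log units; within the scatter) stayed within the scatter. Compound 4 is thus estimated at 110 nM, between 40 nM and 300 nM.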

Compound 4, half-maximal inhibitory concentration in the DU-145 assay: 250 nM
For compound 4 the middle estimate is 2.3-fold (0.36 log units) below the measured one; low and high end bracket the measured number.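

In the DU-145 assay compound 4 gives 250 nM, and bromo in place of chloro gave a 3.3-fold higher number from compound 3 to compound 4 (0.52 log units; beyond the scatter); the two steps for this change on the two cores lie within the scatter of each other: the same change on two cores in the DU-145 assay, a 1.5-fold higher number (0.18 log units; within the scatter) from compound 1 to compound 2 and a 3.3-fold higher number (0.52 log units; beyond the scatter) from compound 3 to compound 4, 2.2-fold (0.35 log units) apart, within the scatter of two such steps. The carboxy group in place of the methoxycarbonyl group gave a 30-fold lower number from compound 2 to compound 4 (1.48 log units; beyond the scatter), and this change also carried from one core to the other: the same change on two cores in the DU-145 assay, a 67-fold lower number (1.82 log units; beyond the scatter) from compound 1 to compound 3 and a 30-fold lower number (1.48 log units; beyond the scatter) from compound 2 to compound 4, 2.2-fold (0.35 log units) apart, within the scatter of two such steps. Both changes together, (4-bromophenyl)(carboxy)methyl in place of (4-chlorophenyl)(methoxycarbonyl)methyl, gave a 20-fold lower number from compound 1 to compound 4 (1.30 log units; beyond the scatter), but two cores with one pair per change do not show that either step would hold on a further core. In a physicochemical assay for solubility (a higher number here means a more soluble compound, a lower number a less soluble compound), compound 3 gives 10000 ug/mL, and compound 4 gives 10000 ug/mL.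

The compounds shown leave open whether fluoro or methyl on that aromatic carbon would fit these steps. They also leave open how an amide in place of the carboxy group would behave.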